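The source may hold more compounds than are shown below. What is called first, only, known or untested is meant among the compounds shown, and "the series" means these compounds.

Measured so far, in a functional assay on MOLM-13 cells (Homo sapiens) for antiproliferative activity; on this read-out higher numbers stand for weaker inhibition and lower numbers for stronger inhibition:
- Compound 1 `Cc1c(-c2ccc(-c3ccccc3F)cc2)nc2ccc(F)cc2c1C(O)C(F)(F)F` gives 640 nM.
- Compound 2 `Cc1c(-c2ccc(-c3ccccc3F)cc2)nc2ccc(F)cc2c1C(=O)C(F)(F)F` gives > 3000 nM, which is a limit of the assay rather than a number.
- Compound 3 `Cc1c(-c2ccc(-c3ccccc3F)cc2)nc2ccc(F)cc2c1-c1noc(=O)[nH]1` gives > 3000 nM, likewise a limit.

Compound 2 therefore stands at the weak end of what has been measured, at the limit of > 3000 nM in this assay, at which 2 of the 3 values shown sit. Its step from compound 1 reads an at least 4.6-fold higher number from compound 1 to compound 2 (0.67 log units; beyond the scatter), and the parallel change gives an at least 4.6-fold higher number from compound 1 to compound 3 (0.67 log units; beyond the scatter); the comparison between compounds 2 and 3 reads a step that the two limits leave unreadable from compound 2 to compound 3.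

The unmeasured compound 4 `Cc1c(-c2ccc(-c3ccccc3F)cc2)nc2ccc(F)cc2c1C(=O)N(C)O` differs from compound 2 by hydroxy(methyl)amino in place of trifluoromethyl on a carbonyl carbon. Among the measured compounds shown here, none of the measured steps touches this part of the molecule in this way: the only group ever varied beside the carbonyl carbon was the group attached to the aromatic carbon, and no compound with hydroxy(methyl)amino has a value. Since compound 2 itself is only a limit, the step from compound 2 to compound 4 cannot be read against any measured pattern, and the expected step of a number no higher from compound 2 to compound 4 (the limit leaves the size open) is set near no change, with wide uncertainty. Compound 4 is therefore estimated at 3000 nM, between 700 nM and 12000 nM, with a fair chance that only a limit is reported again.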

Compound 4, half-maximal inhibitory concentration: 5100 nM
Estimate against measurement, compound 4: 1.7-fold (0.23 log units) below; low and high end bracket the measured number.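

In this assay, the hydroxy(methyl)carbamoyl group gives a real number at this aromatic carbon, and it can be set against the 2,2,2-trifluoro-1-hydroxyethyl group: an 8.0-fold higher number from compound 1 to compound 4 (0.90 log units; beyond the scatter). Compound 1 therefore remains the strongest of the four, as all three other groups shown at this place give weaker inhibition. The steps from compound 2 and compound 3 to compound 4 cannot be read, as those two compounds are held only at a limit: the limit of > 3000 nM in this assay, at which 2 of the 4 values shown sit.

The compounds shown leave open how a plain 1-hydroxyethyl group, without the fluorines, or a carboxylic acid would fare at this aromatic carbon. They also leave open what the hydroxy on the nitrogen of compound 4 contributes, a question that a methylcarbamoyl group would address.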